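This account rests on a few compounds, and the source may have more. Where it says the series, first, only, none or still open, it means among the compounds named here.

Measured so far in a functional assay on 1321-N1 cells for agonist activity at P2Y purinoceptor 6 (Homo sapiens), read by scintillation counting and inositol phosphate accumulation; a higher number here means that more compound is needed for the effect, a lower number that less compound is needed:
Compound 1 `O=c1[nH]/c(=N\OCCCc2ccc(F)cc2)ccn1[C@@H]1O[C@H](COP(=O)(O)OP(=O)(O)OP(=O)(O)O)[C@@H](O)[C@H]1O` gives 1210 nM.
Compound 2 `O=c1[nH]/c(=N\OCCCc2ccc(I)cc2)ccn1[C@@H]1O[C@H](COP(=O)(O)OP(=O)(O)OP(=O)(O)O)[C@@H](O)[C@H]1O` gives 90 nM.

Among the measured compounds shown here, of these two numbers, compound 2 has the lower one, reached by the single measured step of a 13-fold lower number from compound 1 to compound 2 (1.13 log units; beyond the scatter). Compound 3 `O=c1[nH]/c(=N\OCCCc2ccc3ccccc3c2)ccn1[C@@H]1O[C@H](COP(=O)(O)OP(=O)(O)OP(=O)(O)O)[C@@H](O)[C@H]1O` changes the same part of the molecule again: naphthalen-2-yl in place of 4-iodophenyl on a saturated chain carbon, three bonds along the chain from an oxygen. For the measured compounds named here, no measured step swaps one aromatic ring for another, so the change has no direct precedent. Going by the values given here, the one step known, a 13-fold lower number from compound 1 to compound 2 (1.13 log units; beyond the scatter), does show that what sits on the saturated chain carbon three bonds along the chain from an oxygen can move the number a long way, in either direction. With two measured compounds, the direction for compound 3 remains uncertain, and the expected step of a 2.2-fold higher number from compound 2 to compound 3 (0.35 log units; beyond the scatter) is a cautious one. Compound 3 is therefore estimated at 200 nM, with a range from 40 nM to 1000 nM.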

Compound 3, half-maximal effective concentration: 90 nM
The estimate for compound 3 lay 2.2-fold (0.35 log units) above the measured number; the measured number falls inside the stated range.
By their numbers in this assay, from the lowest: compounds 2 and 3 (each within the scatter of the next); then compound 1.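

In this assay the change to naphthalen-2-yl gives no change at the digits printed from compound 2 to compound 3 (within the scatter), so two aromatic rings of carbon only do as well at this place as the one iodine-bearing ring of 4-iodophenyl. The other new step, a 13-fold lower number from compound 1 to compound 3 (1.13 log units; beyond the scatter), matches the earlier gain over 4-fluorophenyl and shows that the low number of compound 2 does not depend on iodine, since compound 3 has none. Nothing available explains why these two different groups give the same number.

Going by these compounds, it remains open whether 4-bromophenyl would also stay level with compound 2 and compound 3, or whether any group at this place could bring the number lower. An amine or a carboxylic acid on the aromatic ring, or a longer chain leading to it, also remains untested among the compounds shown here.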